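Tetrahydroquinoline amine series: rat microsomal stability, compound 4

The source may report more compounds than this note shows. Statements on the series, on what has been measured and on what is new or still open speak of the compounds shown alone.

Measured so far in an ADME assay on microsomes from liver (Rattus norvegicus) for metabolic stability, read by LC-MS, with a stated time of 10 min, tested at 0.5 uM; on this read-out higher numbers stand for a more stable compound and lower numbers for a less stable compound:
- compound 1 `CN1CCN(CCCN(C[C@H]2Cc3ccccc3CN2)[C@H]2CCCc3cccnc32)CC1`: compound 1 gives 10%
- compound 2 `c1ccc2c(c1)CN[C@@H](CN(CC1CCNCC1)[C@H]1CCCc3cccnc31)C2`: compound 2 gives 65%
- compound 3 `c1cnc2c(c1)CCC[C@@H]2N(CCCN1CCNCC1)Cc1nc2ccccc2[nH]1`: compound 3 gives 29%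

Compound 2 stands highest of the three numbers in this assay; compound 3 is the nearest to it and compound 1 the furthest, both gaps beyond the scatter.

Compound 4 `CCN1CCN(CCCN(C[C@H]2Cc3ccccc3CN2)[C@H]2CCCc3cccnc32)CC1` is not yet measured. Against compound 2 the change is 2-(4-ethylpiperazin-1-yl)ethyl in place of piperidin-4-yl on a saturated chain carbon bound to an amine nitrogen.

For the measured compounds named here, one measured step bears directly on this change: a number 55 percentage points higher from compound 1 to compound 2 (beyond the scatter). That step runs in the opposite direction, from a piperazinylethyl substituent to piperidin-4-yl, and compound 4 carries a piperazinylethyl substituent that differs from that of compound 1 only by the ethyl group on the distal nitrogen in place of methyl. The step from compound 2 to compound 4 is therefore expected to be large and downward, roughly the reverse of what was seen from compound 1 to compound 2. Compound 3, which also carries a basic piperazinylpropyl chain, sits well below compound 2 and is consistent with this reading.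

The expected step is a number 50 percentage points lower from compound 2 to compound 4 (beyond the scatter). Compound 4 is thus estimated at 15%, within a range of 3% to 35%.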

Compound 4, percent of the compound remaining: 1%
Compound 4: middle estimate off by 14 percentage points, on the high side; measured number outside the range, below it.
By their numbers in this assay, from the lowest: compounds 4 and 1 (each within the scatter of the next); then compound 3; then compound 2.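

Replacing piperidin-4-yl with 2-(4-ethylpiperazin-1-yl)ethyl on a saturated chain carbon bound to an amine nitrogen gives, in this assay, a number 64 percentage points lower from compound 2 to compound 4 (beyond the scatter), so the large gap first seen with compound 1 recurs with a second piperazine side chain on the same core. Methyl in place of hydrogen on a saturated chain carbon bound to an amine nitrogen in a ring gives a number 9 percentage points lower from compound 1 to compound 4 (within the scatter), so this read-out does not separate the ethyl and methyl end groups, and a smaller end group on the piperazine offers no visible gain over the larger one. No measurement at hand accounts for the gap at this position.

The change from (piperidin-4-yl)methyl to 3-(4-ethylpiperazin-1-yl)propyl alters the ring, its end group and the chain together, so the compounds shown cannot say which of these carries the step. A 3-(piperidin-4-yl)propyl group on the same core would separate chain from ring, and a morpholine ring at the end of the propyl chain would test the distal ring nitrogen.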